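The source may hold more compounds than are shown below. What is called first, only, known or untested is meant among the compounds shown, and "the series" means these compounds.

Measured compounds in an assay on a protein complex (Cavia porcellus) with sulfonylurea receptors; K-ATP channels (Homo sapiens) as the target; on this read-out higher numbers stand for weaker inhibition and lower numbers for stronger inhibition:
compound 1 `CCN(CC)S(=O)(=O)c1ccc(NC(=O)C(C)(O)C(F)(F)F)cc1`, which gives 810 nM;
compound 2 `CN(C)S(=O)(=O)c1ccc(NC(=O)C(C)(O)C(F)(F)F)cc1`, which gives 480 nM.

Going by the values given here, compound 2 carries the smaller of the two numbers, but the only step that separates it from compound 1, a 1.7-fold lower number from compound 1 to compound 2 (0.23 log units; within the scatter), lies within the scatter, so the two compounds cannot be ranked against each other on this read-out. Compound 3 `CC(O)(C(=O)Nc1ccc(S(=O)(=O)N2CCCCC2)cc1)C(F)(F)F` has not yet been measured. It differs from compound 2 in one place: piperidin-1-yl in place of dimethylamino on a sulfonyl sulfur. Among the compounds with values here, the single measured step bears directly on this change, since it also varies the amine on the sulfonyl sulfur; that step, a 1.7-fold lower number from compound 1 to compound 2 (0.23 log units; within the scatter), was too small to register. Enlarging the amine once more, this time into a ring, is therefore expected to move the number little, and in no clear direction beyond the scatter. Compound 3 is estimated at 500 nM in this assay, with a range from 200 nM to 1300 nM. The expected step is a 1.0-fold higher number from compound 2 to compound 3 (0.02 log units; within the scatter), because the measured step of a 1.7-fold lower number from compound 1 to compound 2 (0.23 log units; within the scatter) gives no sign that the amine size matters here.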

Compound 3, half-maximal inhibitory concentration: 9250 nM
Beside the measured number, compound 3's estimate is 19-fold (1.27 log units) below it, outside the stated range (above it).
By their numbers in this assay, from the lowest: compounds 2 and 1 (each within the scatter of the next); then compound 3.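

In this assay, the amine on the sulfonyl sulfur proves able to shift the number strongly, which the earlier pair did not show: dimethylamino and diethylamino stayed within the scatter of each other, whereas piperidin-1-yl gives a 19-fold higher number from compound 2 to compound 3 (1.28 log units; beyond the scatter) and an 11-fold higher number from compound 1 to compound 3 (1.06 log units; beyond the scatter). Going by these compounds alone, compound 3 is the weakest of the three on this read-out and the only one with a ring on the sulfonyl sulfur, while the change from compound 2 leaves the counts of hydrogen-bond donors and acceptors and the net charge as they were. Nothing available here accounts for this large shift.

The three compounds cannot separate the presence of a ring from the particular shape of the piperidin-1-yl group; a pyrrolidine ring, a morpholine ring or an open dipropylamino group on the same sulfonyl sulfur would bear on that question. On these data alone, it also remains open whether the same change would have a similar effect if the rest of the shared core were altered, for example if the trifluoromethyl group gave way to a methyl group.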